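The source may report more compounds than this note shows. Statements on the series, on what has been measured and on what is new or still open speak of the compounds shown alone.

Measured so far in an assay for inhibition of prostacyclin synthase (Homo sapiens), using microsomes; a lower number here means a stronger inhibitor, a higher number a weaker inhibitor:
compound 1, `N#Cc1ccc(C2OCC(C/C=C\CCC(=O)O)C(c3cccnc3)O2)cc1` — > 100000 nM, a limit of the assay
compound 2, `CC(C)(Oc1ccccc1)C1OCC(C/C=C\CCC(=O)O)C(c2cccnc2)O1` — 75000 nM
compound 3, `Cc1ccc(C#N)c(OC(C)(C)C2OCC(C/C=C\CCC(=O)O)C(c3cccnc3)O2)c1` — > 100000 nM, a limit of the assay

Compound 3 stands only at a limit, without a number of its own; (the limit of > 100000 nM in this assay, at which 2 of the 3 values shown sit). Compound 4, `CC(C)(Oc1ccccc1O)C1OCC(C/C=C\CCC(=O)O)C(c2cccnc2)O1`, differs from compound 3 by 2-hydroxyphenyl in place of 2-cyano-5-methylphenyl on an oxygen on a saturated carbon. The step that bears most directly on this change is an at least 1.3-fold higher number from compound 2 to compound 3 (0.12 log units; that floor lies within the scatter), which stays within the scatter; an at least 1.3-fold lower number from compound 1 to compound 2 (0.12 log units; that floor lies within the scatter) concerns the same position of the shared core and also stays within the scatter. Neither step rises above the scatter, so for the change to 2-hydroxyphenyl no step beyond the scatter is expected in this assay, with a fair chance that only a limit is reported again. Compound 4 is expected to give 80000 nM, in the range 20000 nM to 300000 nM. This corresponds to an expected step of an at least 1.2-fold lower number from compound 3 to compound 4 (0.09 log units; that floor lies within the scatter).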

Compound 4, half-maximal inhibitory concentration: > 100000 nM
Compound 4 ended at the assay's limit; the forecaster's own chance of this, stated with the estimate: 45%; at least 1.2-fold (0.09 log units) between middle value and limit.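

In this assay compound 4 gives > 100000 nM, a limit of the assay. Hydroxy in place of hydrogen on an aromatic carbon gives an at least 1.3-fold higher number from compound 2 to compound 4 (0.12 log units; that floor lies within the scatter), so no stronger inhibition shows at this position, and the step between the two limits cannot be read. The substituted phenyl groups on this oxygen, 2-cyano-5-methylphenyl in compound 3 and 2-hydroxyphenyl in compound 4, both end at the same limit: the limit of > 100000 nM in this assay, at which 3 of the 4 values shown sit.

Going by these compounds, how far past that limit compound 3 and compound 4 lie stays open. On these data alone, whether a methoxy or an amine on that phenyl ring would give a measurable number is also open.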